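This account rests on a few compounds, and the source may have more. Where it says the series, first, only, none or still open, it means among the compounds named here.

The read-out throughout is a functional assay on L02 cells (Homo sapiens) for inhibition, read by Griess assay, with stated times of 1 h and 24 h; on this read-out higher numbers stand for weaker inhibition and lower numbers for stronger inhibition. Compound 1 `COc1cccc(CNc2nc(/C=C/c3ccccc3)nc3ccsc23)c1` is one of the two measured compounds. In this assay compound 1 reaches only a limit, > 1000000 nM, an edge of the measurement rather than a number. Compound 2 `COc1cc(/C=C/c2nc(Nc3ccc(C)cc3)c3sccc3n2)cc(OC)c1OC` likewise gives only a limit in this assay, namely < 40000 nM. Compound 2 sits at the limit of < 40000 nM in this assay, at which 1 of the 2 values shown sits. Compound 1 sits at the limit of > 1000000 nM in this assay, at which 1 of the 2 values shown sits. Going by the values given here, these two compounds differ in more than one place, so no single step between them can be read from their values. Compound 3 `COc1cc(/C=C/c2nc(NCc3ccco3)c3sccc3n2)cc(OC)c1OC` has not yet been measured in this assay. It differs from compound 2 in one place: (furan-2-yl)methyl in place of 4-methylphenyl on a nitrogen on an aromatic ring. Among the compounds with values here, no measured pair shows this change, so its size is open. The step from compound 2 to compound 3 is expected to be an at least 1.5-fold higher number from compound 2 to compound 3 (0.17 log units; that floor lies within the scatter), toward weaker inhibition, and it may not clear the usual scatter. For compound 3 the estimated value in this assay is 60000 nM, expected to fall between 15000 nM and 300000 nM.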

Compound 3, half-maximal inhibitory concentration: 189000 nM
The estimate for compound 3 lay 3.2-fold (0.50 log units) below the measured number; the measured number falls inside the stated range.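

Setting (furan-2-yl)methyl in place of 4-methylphenyl on the nitrogen gives, in this assay, an at least 4.7-fold higher number from compound 2 to compound 3 (0.67 log units; beyond the scatter), which is the first sign that inhibition depends on the group at this position, with the change leading to weaker inhibition. Compound 3 gives the only exact number among the compounds shown, 189000 nM, so the step has a firm upper end but marks only the smallest size the change can have. Compound 2 is known only as a limit: the limit of < 40000 nM in this assay, at which 1 of the 3 values shown sits.

This one step changes both the ring and the way it is joined to the nitrogen, so the compounds shown cannot tell which of the two matters. They also leave open how the value would move with a cyclohexyl group or a 2-aminoethyl chain on that nitrogen.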